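This account rests on a few compounds, and the source may have more. Where it says the series, first, only, none or still open, it means among the compounds named here.

Measured so far in an assay on Cerebral cortex for binding affinity to adenosine receptor A1 (Cavia porcellus), read by radioligand binding; a higher number here means a weaker inhibitor, a lower number a stronger inhibitor:
compound 1 `C=CCn1c(=O)c2[nH]cnc2n(CCC)c1=O` gives 1700 nM.
compound 2 `C=CCCn1c(=O)c2[nH]cnc2n(CCC)c1=O` gives 60 nM.
compound 3 `CCCn1c(=O)n(CCC(=O)O)c(=O)c2[nH]cnc21` reaches only the limit of this assay, > 200000 nM.

Among the measured compounds shown here, compound 3 thus stands apart from the other two: its value is a limit and not a number, and it is the one compound that sits at the limit of > 200000 nM in this assay, at which 1 of the 3 values shown sits. The two steps that lead into it are both large and both upward, an at least 110-fold higher number from compound 1 to compound 3 (2.07 log units; beyond the scatter) and an at least 3300-fold higher number from compound 2 to compound 3 (3.52 log units; beyond the scatter); in each the group that enters is the carboxy-bearing chain. Among the neutral chains, a 28-fold lower number from compound 1 to compound 2 (1.45 log units; beyond the scatter) shows the longer chain with the lower number.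

Compound 4 `CCCn1c(=O)n(CCCO)c(=O)c2[nH]cnc21` differs from compound 3 in one place: hydroxymethyl in place of carboxy on a saturated chain carbon, two bonds along the chain from an aromatic nitrogen. For the measured compounds named here, no measured step exchanges carboxy for hydroxymethyl, so the expectation rests on the two steps into compound 3, which both show the carboxy chain carrying the number beyond the range of this assay, and on the neutral-chain compounds 1 and 2, which lie well inside it. Removing the carboxy group is therefore expected to bring the number back down by a large step, an at least 40-fold lower number from compound 3 to compound 4 (1.60 log units; beyond the scatter), though the hydroxyl-bearing chain is not a measured analogue of either neutral chain, so the range is wide. Compound 4 is estimated at 5000 nM, between 500 nM and 50000 nM.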

Compound 4, inhibition constant: 12000 nM
The estimate for compound 4 lay 2.4-fold (0.38 log units) below the measured number, within the range that was stated.
By their numbers in this assay, from the lowest: compound 2; then compound 1; then compound 4. At a limit, above all of these: compound 3.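

In this assay, hydroxymethyl in place of carboxy at this place brings the series back to a measurable number, an at least 16-fold lower number from compound 3 to compound 4 (1.22 log units; beyond the scatter), and the printed counts of hydrogen-bond donors and acceptors are the same for the two groups, so those counts do not separate the two chains. The return is only partial: a 200-fold higher number from compound 2 to compound 4 (2.30 log units; beyond the scatter), and a 7.1-fold higher number from compound 1 to compound 4 (0.85 log units; beyond the scatter), so the 3-hydroxypropyl chain of compound 4 carries a clear cost against both neutral chains, far larger against the longer one. The entry for compound 3 remains a limit and not a number, so the true size of the carboxy-to-hydroxymethyl change is bounded on one side only, and compound 3 stays alone there: the limit of > 200000 nM in this assay, at which 1 of the 4 values shown sits.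

As far as these compounds go, whether the remaining gap to compound 2 follows from the hydroxyl itself or from the chain as a whole stays open, and a methyl ether or an amine at the chain end would help separate the two. A longer chain carrying the hydroxyl, or a methyl ester in place of the carboxylic acid, would show how much of the effect depends on the chain end and how much on its length.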